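Cyanophenyl hydrazone positional swap in the adenosine series

The compounds below may be only part of what the source reports. "The series", "measured", "known", "first", "only" and "open" are said of these compounds alone.

Compound 3 `N#Cc1ccccc1/C=N/Nc1nc(N)c2ncn([C@@H]3O[C@H](CO)[C@@H](O)[C@H]3O)c2n1` gives 2.9 nM in an assay on CHO-K1 cells for displacement of a labelled ligand from adenosine receptor A1 (Homo sapiens), read by scintillation counting, with a stated time of 60 min (a lower number here means a stronger inhibitor, a higher number a weaker inhibitor), the highest of the two numbers shown, with compound 1 `COc1ccc(/C=N/Nc2nc(N)c3ncn([C@@H]4O[C@H](CO)[C@@H](O)[C@H]4O)c3n2)cn1` nearest at 2.6 nM; the gap a 1.1-fold higher number from compound 1 to compound 3 (0.05 log units; within the scatter) is within the scatter. Compound 2 `CSCC/C=N/Nc1nc(N)c2ncn([C@@H]3O[C@H](CO)[C@@H](O)[C@H]3O)c2n1` reaches only the limit > 10000 nM in this assay. The step to compound 4 `N#Cc1ccc(/C=N/Nc2nc(N)c3ncn([C@@H]4O[C@H](CO)[C@@H](O)[C@H]4O)c3n2)cc1` is 4-cyanophenyl in place of 2-cyanophenyl on a carbon with a double bond to nitrogen. Among the measured steps only a 1.1-fold higher number from compound 1 to compound 3 (0.05 log units; within the scatter) compares two aryl groups and it is small, whereas an at least 3800-fold higher number from compound 1 to compound 2 (3.58 log units; beyond the scatter) and an at least 3400-fold lower number from compound 2 to compound 3 (3.53 log units; beyond the scatter) concern the aryl against a chain and say nothing about ring substitution pattern. The change to compound 4 is therefore expected to give a step of a 1.2-fold higher number from compound 3 to compound 4 (0.08 log units; within the scatter), not beyond the scatter, with compound 4 estimated at 3.5 nM, between 1 nM and 12 nM.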

Compound 4, inhibition constant: 4.1 nM
Compound 4: middle estimate off by 1.2-fold (0.07 log units), on the low side; the measured number falls inside the stated range.
By their numbers in this assay, from the lowest: compounds 1, 3 and 4 (each within the scatter of the next). At a limit, above all of these: compound 2.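

In this assay, the place of the nitrile on the phenyl ring makes no difference beyond the scatter, a 1.4-fold higher number from compound 3 to compound 4 (0.15 log units; within the scatter), and 4-cyanophenyl is likewise not separated from 6-methoxypyridin-3-yl, a 1.6-fold higher number from compound 1 to compound 4 (0.20 log units; within the scatter). The large gap to the chain also holds for 4-cyanophenyl, an at least 2400-fold lower number from compound 2 to compound 4 (3.38 log units; beyond the scatter). That step rests on compound 2, whose entry is a limit and not a number: the limit of > 10000 nM in this assay, at which 1 of the 4 values shown sits.

Left open is whether an amine or a carboxylic acid in place of the nitrile keeps the numbers at this level. Also open, from the compounds shown here alone, is whether a longer chain behaves like 2-(methylsulfanyl)ethyl.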